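Phenyl for bromo carried onto a second core

The source may report more compounds than this note shows. Statements on the series, on what has been measured and on what is new or still open speak of the compounds shown alone.

Compound 1 `O=C(N1CCC=C[C@@H]1COCc1ccccc1)n1cc(-c2ccc(-c3ccccc3)cc2)nn1` and compound 2 `O=C(N1CCC=C[C@@H]1COCc1ccccc1)n1cc(-c2ccc(Br)cc2)nn1` share one core; compound 3 `O=C(N1CCC=C[C@@H]1COCc1ccccc1)n1cnc(-c2ccc(Br)cc2)c1` and compound 4 `O=C(N1CCC=C[C@@H]1COCc1ccccc1)n1cnc(-c2ccc(-c3ccccc3)cc2)c1` share another, and the difference between the two cores is not broken down here. In an assay on HEK293 cells for inhibition of diacylglycerol lipase-alpha (Homo sapiens), read by colorimetric assay, with stated times of 30 min, 60 s and 20 min (a lower number here means a stronger inhibitor, a higher number a weaker inhibitor), compound 2 gives 15.9 nM. Compound 1 gives 25.1 nM in this assay, so the change phenyl in place of bromo on an aromatic carbon produced a 1.6-fold higher number from compound 2 to compound 1 (0.20 log units; within the scatter). For compound 3 the read-out in this assay is only a limit, > 10000 nM. The evidence notes (the limit of > 10000 nM in this assay, at which 1 of the 3 values shown sits). Compound 4 carries the same kind of change on the other core, (phenyl in place of bromo on an aromatic carbon), at a place described in the same words. Because a 1.6-fold higher number from compound 2 to compound 1 (0.20 log units; within the scatter) lies within the scatter, the step expected for compound 4 is a step that the limit leaves unreadable from compound 3 to compound 4. Compound 4 is therefore estimated at 20000 nM in this assay, between 6000 nM and 100000 nM, and most probably again reported only as a limit.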

Compound 4, half-maximal inhibitory concentration: > 10000 nM
Compound 4: no number, only a limit; the forecaster's own chance of this, stated with the estimate: 85%; the middle value does not contradict the limit.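

Compound 3 and compound 4 both stand only as limits in this assay, and no step can be read between them: the limit of > 10000 nM in this assay, at which 2 of the 4 values shown sit.

The compounds shown leave open what phenyl in place of bromo does on the core of compound 3.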